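Cytotoxicity notes: aryl swap at the para position

The source may hold more compounds than are shown below. What is called first, only, known or untested is meant among the compounds shown, and "the series" means these compounds.

Measured so far:
compound 1, `CC(C)N(Cc1cccc(OCCCCCC(=O)O)c1)C(=O)c1ccc(-c2cc3ccccc3n2S(=O)(=O)c2ccccc2)cc1`; in an ADME assay on HEK293 cells (Homo sapiens) for cytotoxicity, read by CellTiter-Glo and resazurin assay, with a stated time of 72 h (on this read-out higher numbers stand for an effect only at larger amounts of compound and lower numbers for an effect already at smaller amounts), compound 1 gives > 26000 nM
compound 2, `CCOC(=O)CCCCCOc1cccc(CN(C(=O)c2ccc(-c3cccc(N(C)C)c3)cc2)C(C)C)c1`; in this assay compound 2 gives > 26000 nM

For compound 2 the value in this assay is a limit of the assay, not a number. It stands at the limit of > 26000 nM in this assay, at which 2 of the 2 values shown sit. The value of compound 1 is a limit as well. Among the compounds with values here, no step between two measured compounds is available, so no size of effect for any structural change has been measured here.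

Compound 3, `CCOC(=O)CCCCCOc1cccc(CN(C(=O)c2ccc(-c3cc(F)cc(OC)c3)cc2)C(C)C)c1`, is still to be measured in this assay. It differs from compound 2 in one place: 3-fluoro-5-methoxyphenyl in place of 3-(dimethylamino)phenyl on an aromatic carbon.

With both measured values sitting at the limit, the step is expected to be none beyond the scatter, estimated as a step that the limit leaves unreadable from compound 2 to compound 3. Compound 3 is expected to give 30000 nM, in the range 15000 nM to 60000 nM, most probably reported again as a limit of the assay rather than a number.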

Compound 3, half-maximal effective concentration: > 26000 nM
Compound 3 ended at the assay's limit; the forecaster's own chance of this, stated with the estimate: 85%; the middle value is on the limit's open side.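

In this assay compound 3 gives > 26000 nM and this is a limit of the assay, not a number. Within the data shown here, compound 2 also stands at a limit, and no step from it to compound 3 can be read. The compounds shown leave open at what concentration any of them affects these cells.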